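The source may hold more compounds than are shown below. What is called first, only, known or untested is meant among the compounds shown, and "the series" means these compounds.

Compound 2 `CN1C/C(=C\c2cccnc2)C(=O)/C(=C/c2ccccc2C(F)(F)F)C1` gives 14100 nM in an ADME assay on L02 cells (Homo sapiens) for cytotoxicity, read by MTT assay, with a stated time of 24 h; a higher number here means a weaker inhibitor, a lower number a stronger inhibitor. Compound 1 `COc1cc(/C=C2\CN(C)C/C(=C\c3cccnc3)C2=O)cc(OC)c1OC` gives 14400 nM in this assay, and compound 3 `CN1C/C(=C\c2ccncc2)C(=O)/C(=C/c2ccccc2C(F)(F)F)C1` gives 15800 nM. Compound 2 has the lowest of these three numbers, but every gap to it lies within the scatter. Going by the values given here, the only single-point step among them is a 1.1-fold higher number from compound 2 to compound 3 (0.05 log units; within the scatter), which concerns the pyridinyl group, not the ring nitrogen.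

Compound 4 `O=C1/C(=C/c2cccnc2)CN(S(=O)(=O)c2ccc(Br)cc2)C/C1=C\c1ccccc1C(F)(F)F` differs from compound 2 by (4-bromophenyl)sulfonyl in place of methyl on an amine nitrogen in a ring. Among the compounds with values here, no measured step touches the substituent on that nitrogen, so nothing here points to a direction beyond the scatter. The number for compound 4 is therefore expected to stay close to compound 2, with a 1.0-fold lower number from compound 2 to compound 4 (0.00 log units; within the scatter), giving an estimate of 14000 nM (range 5000 nM to 40000 nM).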

Compound 4, half-maximal inhibitory concentration: 13300 nM
Compound 4: middle estimate off by 1.1-fold (0.02 log units), on the high side, and the stated range covers the measured number.
By their numbers in this assay, from the lowest: compounds 4, 2, 1 and 3 (each within the scatter of the next).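

Going by these compounds alone, this is the first step at the amine nitrogen in the ring: in this assay, (4-bromophenyl)sulfonyl in place of methyl gives a 1.1-fold lower number from compound 2 to compound 4 (0.03 log units; within the scatter). Even a group that brings in a six-membered aromatic ring and a sulfonyl leaves the number within the scatter at this position. Nothing measured here offers any reason for this.

Going by these compounds, whether a carboxylic acid or a longer amine chain on this nitrogen would move the number beyond the scatter stays open. So does whether the same swap would hold with the pyridin-4-yl group of compound 3.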